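Working notes: the step to 4-ethylphenyl

The compounds below may be only part of what the source reports. "The series", "measured", "known", "first", "only" and "open" are said of these compounds alone.

compound 1 `COC1=C(C)C(=O)/C(=C(O)/C=C/c2cccc(OC)c2)C(=O)C1(C)C` gives 2.4 ug/mL
compound 2 `COC1=C(C)C(=O)/C(=C(O)/C=C/c2ccc(O)cc2)C(=O)C1(C)C` gives 3 ug/mL
compound 3 `CCc1ccc(/C=C/C(O)=C2/C(=O)C(C)=C(OC)C(C)(C)C2=O)cc1` is not yet measured

For the measured compounds named here, in a functional assay on KB cells (Homo sapiens) for cytotoxicity (on this read-out higher numbers stand for an effect only at larger amounts of compound and lower numbers for an effect already at smaller amounts), compound 2 stands within the scatter of compound 1, the only other measured compound. The change to compound 3 is ethyl in place of hydroxy on an aromatic carbon and amounts to ethyl in place of hydroxy on an aromatic carbon. Going by the values given here, the one measured step bearing on it is a 1.3-fold higher number from compound 1 to compound 2 (0.10 log units; within the scatter) and that step also exchanged a group on this aromatic ring. Among the compounds with values here, with only that step to go on, the estimate is a 1.2-fold lower number from compound 2 to compound 3 (0.08 log units; within the scatter) and no shift beyond the scatter is expected. Compound 3 is expected at 2.5 ug/mL in this assay with an estimated range (1 ug/mL to 6 ug/mL).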

Compound 3, concentration for half-maximal effect: 1.9 ug/mL
Estimate against measurement, compound 3: 1.3-fold (0.12 log units) above, within the range that was stated.
By their numbers in this assay, from the lowest: compounds 3, 1 and 2 (each within the scatter of the next).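

In this assay the aromatic carbon para to a large group accepts ethyl as well as hydroxy: a 1.6-fold lower number from compound 2 to compound 3 (0.20 log units; within the scatter), so the hydrogen-bond donor and acceptor counted for hydroxy are not needed to hold the read-out. Exchange of 3-methoxyphenyl for 4-ethylphenyl gives the same picture: a 1.3-fold lower number from compound 1 to compound 3 (0.10 log units; within the scatter). No measurement at hand bears on why this position responds so little.

On these data alone, whether an amine, a carboxylic acid or a chain longer than ethyl at this carbon would move the read-out beyond the scatter remains open.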